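A few compounds are considered here, and "the series" means these few. Any claim that something is new, unique, unknown or untested is made for them only; others in the source may bear on it.

Notes on the series. Compound 1 `COC(=O)c1cc(=O)c2c(OC)cc(OC)cc2n1C` carries a methyl ester on the shared core. In a functional assay on KOPN-8 cells (Homo sapiens) for antiproliferative activity, with a stated time of 72 h (on this read-out higher numbers stand for an effect only at larger amounts of compound and lower numbers for an effect already at smaller amounts), compound 1 reaches only the assay limit of > 19000 nM. Compound 2 `COc1ccc(-c2cc(=O)c3c(OC)cc(OC)cc3n2S(=O)(=O)c2ccc(C)c([N+](=O)[O-])c2)cc1` carries the 4-methyl-3-nitrophenyl group on the same core. In this assay compound 2 also gives only a limit, > 51700 nM. That is where compound 2 stands: both values shown are limits (the limit of > 19000 nM in this assay, at which 1 of the 2 values shown sits, (the limit of > 51700 nM in this assay, at which 1 of the 2 values shown sits)), so no numbered potency is known for either. Compound 3 `COc1ccc(-c2cc(=O)c3c(OC)cc(OC)cc3n2S(=O)(=O)c2ccc(C)cc2)cc1` has not been measured. It differs from compound 2 in one place: hydrogen in place of nitro on an aromatic carbon. Among the compounds with values here, no measured pair of this kind exists here, so the size of this step cannot be read from data. Because compound 2 sits at the limit > 51700 nM, the expectation in this assay is no step beyond the scatter, most likely again a limit. The expected step is a step that the limit leaves unreadable from compound 2 to compound 3. Compound 3 is estimated at 60000 nM, within 10000 nM to 200000 nM.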

Compound 3, half-maximal effective concentration: > 44800 nM
Compound 3 ended at the assay's limit (the forecaster's own chance of this, stated with the estimate: 85%); the middle value is on the limit's open side.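

In this assay compound 3 gives only a limit, > 44800 nM. Compound 2 is also only a limit, > 51700 nM, so no step can be read between compound 2 and compound 3. The compounds shown leave open whether nitro or hydrogen at this place makes any difference to potency in this assay.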